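A few compounds are considered here, and "the series" means these few. Any claim that something is new, unique, unknown or untested is made for them only; others in the source may bear on it.

Compound 1 `C[C@@H]1CN(c2ncc(OCc3ccc(S(C)(=O)=O)cc3)cn2)CCN1C(=O)OC(C)(C)C`: 16%
Compound 2 `CC(C)(C)OC(=O)N1C[C@@H]2C[C@H]1CN2c1ncc(OCc2ccc(S(C)(=O)=O)cc2)cn1`: 1%
Compound 3 `C[C@@H]1CN(C(=O)OC(C)(C)C)CCN1c1ncc(OCC2CCN(S(C)(=O)=O)CC2)cn1`: 67%

In a functional assay on isolated protein with Glucose-dependent insulinotropic receptor (Mus musculus) as the target, read by HTRF and cAMP accumulation, with a stated time of 45 min (on this read-out lower numbers stand for smaller maximal responses and higher numbers for larger maximal responses), compound 3 gives 67%, the highest of the three numbers. Compound 1 gives 16% and compound 2 gives 1%, and both of these lie beyond the scatter below compound 3. Compound 4 `C[C@@H]1CN(C(=O)OC(C)(C)C)CCN1c1ncc(OCc2ccc(S(C)(=O)=O)cc2F)cn1` has not yet been measured. It differs from compound 3 in a single place: 2-fluoro-4-(methylsulfonyl)phenyl in place of 1-(methylsulfonyl)piperidin-4-yl on a saturated chain carbon bound to an oxygen on an aromatic ring. Among the compounds with values here, no pair of measured compounds differs by exactly this change, so the step cannot be read off directly. What the numbers do show is that compound 1, which also carries an aromatic ring bearing methylsulfonyl on the chain carbon bound to the oxygen, though with a different arrangement of the shared core, sits far below compound 3. On that basis a downward step beyond the scatter is expected in this assay for compound 4. Compound 4 is estimated at 25%, within a range from 5% to 50%. This estimate means an expected step of a number 42 percentage points lower from compound 3 to compound 4 (beyond the scatter).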

Compound 4, intrinsic activity: the largest response reached, in percent of the reference agonist's: 90%
For compound 4 the middle estimate is 65 percentage points below the measured one; the whole stated range lies below it.
By their numbers in this assay, from the lowest: compound 2; then compound 1; then compound 3; then compound 4.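

In this assay, 2-fluoro-4-(methylsulfonyl)phenyl in place of 1-(methylsulfonyl)piperidin-4-yl on a saturated chain carbon bound to an oxygen on an aromatic ring gives a number 23 percentage points higher from compound 3 to compound 4 (beyond the scatter), so this position keeps a large maximal response with an aromatic ring of carbon only. Within the data shown here, this is the first direct reading of the position, and the steps among the earlier compounds cannot be read. Nothing measured here accounts for the gain.

The fluorine and the phenyl ring enter together, so the compounds shown leave open how much of the step belongs to each. Also open, as far as these compounds go, is how this assay would read for the same ring without fluorine, or with a nitrile or a carboxylic acid in place of the methylsulfonyl group.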